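The compounds below may be only part of what the source reports. "The series", "measured", "known", "first", "only" and "open" are said of these compounds alone.

Measured so far in a functional assay on HCT-116 cells (Homo sapiens) for inhibition, read by MTT assay, with a stated time of 48 h; a lower number here means a stronger inhibitor, a higher number a weaker inhibitor:

Compound 1 `COc1ccc(CNc2cc(OC)c(OC)c(OC)c2)cc1[N+](=O)[O-]`: 18200 nM
Compound 2 `COC(=O)c1cc(CNc2cc(OC)c(OC)c(OC)c2)ccc1OC`: 38100 nM
Compound 3 `COc1ccc(CN(C(=O)CCCl)c2cc(OC)c(OC)c(OC)c2)cc1O`: 150 nM

Among these three, compound 2 has the highest number, at 38100 nM. The nearest neighbour is compound 1 at 18200 nM, while compound 3 lies far lower at 150 nM. For the measured compounds named here, compound 3 differs from compound 2 in more than one place, so it offers no single-change step to work from.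

The next compound is compound 4 `COc1ccc(CNc2cc(OC)c(OC)c(OC)c2)cc1C`, which has methyl in place of methoxycarbonyl on an aromatic carbon, ortho to a methoxy group (methyl in place of methoxycarbonyl on an aromatic carbon). The exchange removes the whole ester group and leaves a single carbon.

Going by the values given here, only one measured step bears on this place: methoxycarbonyl in place of nitro on an aromatic carbon, which gave a 2.1-fold higher number from compound 1 to compound 2 (0.32 log units; beyond the scatter). That step lies beyond the scatter but is modest. Among the compounds with values here, no measured compound carries methyl here, so the evidence is thin. On that basis, only a small change in this assay is expected, perhaps slightly downward and probably not beyond the scatter. The expected change is a 1.5-fold lower number from compound 2 to compound 4 (0.18 log units; within the scatter). For compound 4 the estimate is 25000 nM, with an expected range from 10000 nM to 60000 nM.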

Compound 4, half-maximal inhibitory concentration: 60900 nM
Compound 4: middle estimate off by 2.4-fold (0.39 log units), on the low side; measured number above the stated range.
By their numbers in this assay, from the lowest: compound 3; then compound 1; then compounds 2 and 4 (each within the scatter of the next).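

In this assay, replacing methoxycarbonyl with methyl on this aromatic carbon, ortho to a methoxy group, gives a 1.6-fold higher number from compound 2 to compound 4 (0.20 log units; within the scatter) and so does not separate the two groups, even though the hydrogen-bond acceptors counted on methoxycarbonyl are absent from methyl. Set against nitro, methyl gives a 3.3-fold higher number from compound 1 to compound 4 (0.52 log units; beyond the scatter) and methoxycarbonyl gives a 2.1-fold higher number from compound 1 to compound 2 (0.32 log units; beyond the scatter) in the same assay, so among these three compounds only nitro stands apart, and by a modest margin on each step. No measurement is available here that would explain this result.

The compounds shown leave open whether an amine or a carboxylic acid on this carbon would stand with nitro, with methyl and methoxycarbonyl, or apart from both. They also leave open how much of the far lower number of compound 3, at 150 nM in this assay, belongs to this position, since that compound differs from the others in more than one place, including the chloropropanoyl group on its nitrogen.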